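Swapping amino for chloro on the shared core

A few compounds are considered here, and "the series" means these few. Any claim that something is new, unique, unknown or untested is made for them only; others in the source may bear on it.

Measured in a functional assay on KB cells (Homo sapiens) for inhibition; a higher number here means a weaker inhibitor, a lower number a stronger inhibitor:
- Compound 1 `Cc1ccc(Cn2c(N)nc3cc(Cl)c(Cl)cc32)cc1`: 50000 nM
- Compound 2 `Nc1nc2cc(Cl)c(Cl)cc2n1Cc1ccc([N+](=O)[O-])cc1`: 35000 nM
- Compound 3 `Nc1nc2cc(Cl)c(Cl)cc2n1Cc1ccc(F)cc1`: 70000 nM

In this assay, compound 3 stands level with compound 1 and compound 2, as all three values lie within the scatter of one another. Compound 4 `Fc1ccc(Cn2c(Cl)nc3cc(Cl)c(Cl)cc32)cc1` carries chloro in place of amino on an aromatic carbon, between two ring nitrogen atoms (chloro in place of amino on an aromatic carbon).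

The measured steps exchange only methyl, nitro and fluoro: a 1.4-fold lower number from compound 1 to compound 2 (0.15 log units; within the scatter), a 1.4-fold higher number from compound 1 to compound 3 (0.15 log units; within the scatter) and a 2.0-fold higher number from compound 2 to compound 3 (0.30 log units; within the scatter). Each stays within the scatter, but none touches the place that changes here. The data therefore hold no direct measure of losing the amino group, and they offer no reason to expect a shift beyond the scatter in either direction. The expected change is small, a 1.8-fold lower number from compound 3 to compound 4 (0.24 log units; within the scatter). The estimate for compound 4 is 40000 nM, with an expected range from 12000 nM to 100000 nM.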

Compound 4, half-maximal inhibitory concentration: > 100000 nM
Compound 4 gave a limit, no number (the forecaster's own chance of this, stated with the estimate: 20%); at least 2.5-fold (0.39 log units) between middle value and limit.
By their numbers in this assay, from the lowest: compounds 2, 1 and 3 (each within the scatter of the next). At a limit, above all of these: compound 4.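

In this assay, among the compounds shown here, compound 4 gives > 100000 nM, which is a limit and not a number, and it is the first result here from a change on the aromatic carbon between two ring nitrogen atoms. Chloro in place of amino at this position gives an at least 1.4-fold higher number from compound 3 to compound 4 (0.15 log units; that floor lies within the scatter), so the data fix only a floor for this change, whereas the exchanges of methyl, nitro and fluoro all gave numbers. The limit sets compound 4 apart from the other compounds only in the form of its result: the limit of > 100000 nM in this assay, at which 1 of the 4 values shown sits.

As far as these compounds go, the true size of the step remains open, as does whether it follows from losing amino or from bringing in chloro. A methylamino or a hydroxyl group at this position, or a bare hydrogen, would help separate those two readings.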